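Swapping a methyl for a fluorine on the benzyl arm

The source may hold more compounds than are shown below. What is called first, only, known or untested is meant among the compounds shown, and "the series" means these compounds.

Three compounds share one core and differ only in the group carried on the amide-type nitrogen. Compound 1, `COc1ccc2c(=O)c(/C=C/C(=O)NCc3cccc(F)c3)coc2c1`, bears a 3-fluorobenzyl there and gives 17600 nM in a functional assay on HeLa cells (Homo sapiens) for inhibition, read by MTT assay, with a stated time of 48 h; on this read-out lower numbers stand for stronger inhibition and higher numbers for weaker inhibition. Compound 2, `COc1ccc2c(=O)c(/C=C/C(=O)Nc3ccc(Cl)cc3)coc2c1`, with a 4-chlorophenyl in that place, reaches only the limit of the assay, > 100000 nM. Compound 3, `COc1ccc2c(=O)c(/C=C/C(=O)NCc3ccc(C)cc3)coc2c1`, with a 4-methylbenzyl, likewise gives only the limit > 100000 nM. Compound 3 thus stands at a limit rather than a number, and one further value shown is a limit too, so that two of the three values sit at the limit of > 100000 nM in this assay, at which 2 of the 3 values shown sit. The steps read an at least 5.6-fold higher number from compound 1 to compound 2 (0.75 log units; beyond the scatter) and an at least 5.6-fold higher number from compound 1 to compound 3 (0.75 log units; beyond the scatter), while a step that the two limits leave unreadable from compound 2 to compound 3.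

Compound 4, `COc1ccc2c(=O)c(/C=C/C(=O)NCc3ccccc3F)coc2c1`, differs from compound 3 as follows: 2-fluorophenyl in place of 4-methylphenyl on a saturated chain carbon bound to an amide-type nitrogen. Among the compounds with values here, the step that bears on this change is an at least 5.6-fold higher number from compound 1 to compound 3 (0.75 log units; beyond the scatter), where exchanging a fluorophenyl for a methylphenyl cost at least modest potency; putting a fluorophenyl back, though in a different pattern, could recover part of that loss, with compound 1 the only real number to anchor it. The estimate therefore expects an at least 2.5-fold lower number from compound 3 to compound 4 (0.39 log units; beyond the scatter), a lower number. Compound 4 is expected to give 40000 nM, within 12000 nM to 120000 nM.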

Compound 4, half-maximal inhibitory concentration: > 100000 nM
Compound 4: only a limit was reported; the forecaster's own chance of this, stated with the estimate: 35%; at least 2.5-fold (0.39 log units) between middle value and limit.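

Within the data shown here, the one readable new step, in this assay, is an at least 5.6-fold higher number from compound 1 to compound 4 (0.75 log units; beyond the scatter), and it shows that 2-fluorobenzyl does not keep the measured value that 3-fluorobenzyl gives on the amide-type nitrogen. Among these compounds, a fluorine on the ring of the benzyl arm is therefore not enough by itself to give a number, and compound 1 is now the only one of the four compounds with a number rather than a limit. The other two new steps cannot be read because both ends of each sit at the same limit: the limit of > 100000 nM in this assay, at which 3 of the 4 values shown sit.

From the compounds shown here alone, it remains open whether a 4-fluorobenzyl or a 3-chlorobenzyl on the amide-type nitrogen would give a number, as compound 1 does, or would also sit at the limit. A phenethyl group in that place, which would test a longer chain, is also left open, as is the question of whether any group there can give a lower number than compound 1 gives.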